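The compounds below may be only part of what the source reports. "The series", "measured", "known", "first", "only" and "open" are said of these compounds alone.

Measured in a functional assay on CHO-K1 cells for antagonist activity at transient receptor potential cation channel subfamily V member 1 (Homo sapiens), read by FLIPR; a higher number here means a weaker inhibitor, a lower number a stronger inhibitor:

Compound 1 `CC(C(=O)NCc1ccc(C(F)(F)F)nc1NC1CCCCC1)c1ccc(NS(C)(=O)=O)c(F)c1` gives 20.4 nM.
Compound 2 `CC(C(=O)NCc1ccc(C(F)(F)F)nc1Nc1ccccc1)c1ccc(NS(C)(=O)=O)c(F)c1` gives 59.6 nM.
Compound 3 `Cc1ccc(Cl)cc1Nc1nc(C(F)(F)F)ccc1CNC(=O)C(C)c1ccc(NS(C)(=O)=O)c(F)c1` gives 14 nM.

Compound 3 has the lowest of the three numbers, though compound 1 lies within the scatter of it; only compound 2 is clearly separated, a 4.3-fold lower number from compound 2 to compound 3 (0.63 log units; beyond the scatter). Compound 4 `CC(C(=O)NCc1ccc(C(F)(F)F)nc1N(C)C)c1ccc(NS(C)(=O)=O)c(F)c1` differs from compound 3 by dimethylamino in place of (5-chloro-2-methylphenyl)amino on an aromatic carbon. For the measured compounds named here, two measured steps touch this position: a 1.5-fold lower number from compound 1 to compound 3 (0.16 log units; within the scatter) and a 4.3-fold lower number from compound 2 to compound 3 (0.63 log units; beyond the scatter), both changes of one ring group for another. Going by the values given here, no measured step removes the ring altogether, so the new change reaches outside what was seen. Compound 4 is therefore expected to give a higher number, an 11-fold higher number from compound 3 to compound 4 (1.03 log units; beyond the scatter), with an estimate of 150 nM and a range from 40 nM to 600 nM.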

Compound 4, inhibition constant: 19.1 nM
For compound 4 the middle estimate is 7.9-fold (0.90 log units) above the measured one; the whole stated range lies above it.
By their numbers in this assay, from the lowest: compounds 3, 4 and 1 (each within the scatter of the next); then compound 2.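

In this assay the ring at this position proves dispensable: dimethylamino, with no ring and no hydrogen-bond donor, stays level with both larger groups (a 1.4-fold higher number from compound 3 to compound 4 (0.13 log units; within the scatter); a 1.1-fold lower number from compound 1 to compound 4 (0.03 log units; within the scatter)). Only the anilino compound falls out of line (a 3.1-fold lower number from compound 2 to compound 4 (0.49 log units; beyond the scatter)), so among these four compounds a large group is not needed here, and compound 2 is the exception among the groups tried. Nothing available explains this tolerance. Still open, going by these compounds, is how a pyrrolidine or morpholine would compare at this carbon. An unsubstituted amino group or a methoxy group there also remains untested in the compounds shown.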